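The source may report more compounds than this note shows. Statements on the series, on what has been measured and on what is new or still open speak of the compounds shown alone.

In an assay for inhibition of MAP kinase-interacting serine/threonine-protein kinase 2 (Homo sapiens), read by luminescence and ADP-Glo, with a stated time of 2 h (on this read-out higher numbers stand for weaker inhibition and lower numbers for stronger inhibition), compound 2 `CC(=O)Nc1cccc(Cn2cc(-c3ccc4cn[nH]c4c3)ccc2=O)c1` gives 43 nM, the lower of the two numbers reported. Compound 1 `O=c1ccc(-c2ccc3cn[nH]c3c2)cn1Cc1ccccc1C(F)(F)F` gives 100 nM in this assay, a gap that lies beyond the usual scatter. Compound 3 `Cn1ncc2ccc(-c3ccc(=O)n(Cc4ccccc4)c3)cc21` reaches only > 2000 nM in this assay, which is a limit of the assay rather than a number (the limit of > 2000 nM in this assay, at which 1 of the 3 values shown sits). Compound 4 `Nc1cccc(Cn2cc(-c3ccc4cn[nH]c4c3)ccc2=O)c1` differs from compound 2 by hydrogen in place of acetyl on a nitrogen on an aromatic ring; cut one bond further out, the change reads acetamido to amino. Going by the values given here, no pair of measured compounds shows this change, so its size is unknown from the data. A modest weakening is expected, a step of a 2.1-fold higher number from compound 2 to compound 4 (0.32 log units; beyond the scatter) in this assay, close to the edge of the scatter. Compound 4 is therefore estimated at 90 nM, with a range from 30 nM to 300 nM.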

Compound 4, half-maximal inhibitory concentration: 84 nM
The estimate for compound 4 lay 1.1-fold (0.03 log units) above the measured number; the measured number falls inside the stated range.
By their numbers in this assay, from the lowest: compounds 2, 4 and 1 (each within the scatter of the next, the first and the last beyond it). At a limit, above all of these: compound 3.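

Here a single change can be read for the first time: on a nitrogen on an aromatic ring, hydrogen in place of acetyl gives a 2.0-fold higher number from compound 2 to compound 4 (0.29 log units; within the scatter) in this assay. The acetyl is therefore not needed at this place for the number to hold within the scatter. Nothing measured here gives a reason for this step. The compounds shown leave open how a longer acyl chain or a methanesulfonyl group on this nitrogen would read in this assay. They also leave open whether a carboxylic acid could take the place of the nitrogen.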